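Flipping one stereocentre in compound 1

The source may hold more compounds than are shown below. What is called first, only, known or untested is meant among the compounds shown, and "the series" means these compounds.

In an ADME assay on L1210 cells (Mus musculus) for cytotoxicity, with a stated time of 48 h (on this read-out higher numbers stand for weaker inhibition and lower numbers for stronger inhibition), compound 1 (`C=C1[C@H](C)CCC[C@]1(C)CC/C(C)=C/CC1=C(O)C(=O)C=C(N[C@@H](C(=O)O)[C@H](C)O)C1=O`) gives 4.6 ug/mL as its value. For the measured compounds named here, in the same read-out compound 2 (`C=C1[C@H](C)CCC[C@]1(C)CC/C(C)=C/CC1=C(O)C(=O)C=C(N[C@H](CO)C(=O)O)C1=O`) gives 2.6 ug/mL as its value, which places compound 1 within the usual scatter of the only other exact number. Compound 3 (`CC1=CCC[C@](C)(CC/C(C)=C/CC2=C(O)C(=O)C=C(N[C@@H](CO)C(=O)O)C2=O)[C@@H]1C`) gives > 10 ug/mL in this assay (a limit, not a number).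

Compound 4 (`C=C1[C@H](C)CCC[C@]1(C)CC/C(C)=C/CC1=C(O)C(=O)C=C(N[C@H](C(=O)O)[C@H](C)O)C1=O`) is still unmeasured, and from compound 1 to it the two compounds have the same atoms and bonds and differ only in configuration as drawn: 1 of 5 stereo elements differ; a stereocentre at a saturated chain carbon is drawn R in compound 1 and S in compound 4 (no group leaves or enters). Going by the values given here, no measured step alters this configuration alone. Among the compounds with values here, the only measured step is a 1.8-fold lower number from compound 1 to compound 2 (0.25 log units; within the scatter) for hydrogen in place of methyl, which is a different change and so offers only a weak guide. It does show that this one change left the number within the scatter, but it says nothing direct about a flipped stereocentre. With no direct evidence for a shift in either direction, no step beyond the scatter is expected in this assay and the range has to stay wide. The expected step is a 1.1-fold higher number from compound 1 to compound 4 (0.04 log units; within the scatter) and no larger than that. Compound 4 is expected at about 5 ug/mL with an estimated range from 2 ug/mL to 12 ug/mL overall.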

Compound 4, half-maximal inhibitory concentration: > 10 ug/mL
Compound 4: no number, only a limit (the forecaster's own chance of this, stated with the estimate: 20%); middle value at least 2.0-fold (0.30 log units) away from the limit.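

For the compounds shown here, until now the only step on the group attached to the amine nitrogen, hydrogen in place of methyl, had stayed within the scatter, so this part of the molecule looked tolerant of change. In this assay, flipping a single stereocentre, with no group leaving or entering, produces a clear loss of strength: an at least 2.1-fold higher number from compound 1 to compound 4 (0.33 log units; beyond the scatter) is the step. The same loss shows against the smaller group of compound 2, with an at least 3.8-fold higher number from compound 2 to compound 4 (0.58 log units; beyond the scatter), and the shift can be tied to the configuration at that one carbon alone because of this: the fact that compounds 1 and 4 differ only in the configuration as drawn.

From the compounds shown here alone, how far compound 4 really lies from the other compounds stays open, because its result is a limit and not a number: the limit of > 10 ug/mL in this assay, at which 2 of the 4 values shown sit. Also open, going by these compounds, is how a methyl ester in place of the carboxylic acid on this group would read in either configuration, and so whether the sensitivity to configuration depends on the acid being present.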